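Amide-linked aryl series: chloro for methyl on distal ring

The source may hold more compounds than are shown below. What is called first, only, known or untested is meant among the compounds shown, and "the series" means these compounds.

Measured so far in a functional assay on IGROV-1 cells (Homo sapiens) for inhibition, read by sulforhodamine B assay, tested at 10 uM; on this read-out higher numbers stand for more inhibition at the one concentration tested (going by the name of the read-out) and lower numbers for less inhibition:
compound 1 `COc1cc2oc(-c3cccc(NC(=O)c4ccc(Br)cc4)c3)cc(=O)c2c(OC)c1OC` gives 52.9%
compound 2 `COc1cc2oc(-c3cccc(NC(=O)c4ccc([N+](=O)[O-])cc4)c3)cc(=O)c2c(OC)c1OC` gives 57.3%
compound 3 `COc1cc2oc(-c3cccc(C(=O)Nc4ccc(C)cc4)c3)cc(=O)c2c(OC)c1OC` gives 51.8%

Compound 3 holds the lowest of the three numbers in this assay, but its nearest neighbour compound 1 sits only a number 1.1 percentage points lower from compound 1 to compound 3 (within the scatter) away, a gap within the scatter, and its gap to compound 2 is also within the scatter. On these numbers the three compounds cannot be told apart.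

Compound 4 `COc1cc2oc(-c3cccc(C(=O)Nc4ccc(Cl)cc4)c3)cc(=O)c2c(OC)c1OC` is the next member. It differs from compound 3 as follows: chloro in place of methyl on an aromatic carbon. One measured step resembles this one in kind, a swap of one substituent for another on the outer ring: a number 4.4 percentage points higher from compound 1 to compound 2 (within the scatter), which stayed within the scatter. The other step, a number 1.1 percentage points lower from compound 1 to compound 3 (within the scatter), changes both the linker orientation and the substituent at once and is less informative, yet it too stayed within the scatter. For the measured compounds named here, nothing so far shows that a change on the outer ring moves this assay beyond its scatter.

For compound 4 the expected step is therefore a number 0.2 percentage points higher from compound 3 to compound 4 (within the scatter), no shift beyond the scatter in either direction. Compound 4 is estimated at 52%, with a range from 40% to 64%.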

Compound 4, a percentage reported as inhibition, at one concentration (the size of the read-out at that concentration, not a potency): 56.9%
Compound 4: middle estimate off by 4.9 percentage points, on the low side, within the range that was stated.
By their numbers in this assay, from the lowest: compounds 3, 1, 4 and 2 (each within the scatter of the next).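

In this assay, for the compounds shown here, chloro in place of methyl, para to a large group on the outer ring, gives a number 5.1 percentage points higher from compound 3 to compound 4 (within the scatter); this is the first swap at this position read with the carbamoyl link held fixed. Together with the bromo to nitro step on the reversed amide, it means that in both amide orientations shown, the one substituent swap available leaves the read-out within its scatter, although both swaps cover only a small set of groups. The combined change gives a number 4 percentage points higher from compound 1 to compound 4 (within the scatter), which cannot separate the effect of the linker orientation from that of the halogen, and no supporting data bear on this result.

The compounds shown leave open whether an amine, a carboxylic acid or a longer chain such as butyl at this position would move this assay beyond its scatter, since methyl, chloro, bromo and nitro alone do not settle that. They also leave open whether these four compounds, indistinguishable at the one concentration tested, would separate in a full concentration-response measurement.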